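A few compounds are considered here, and "the series" means these few. Any claim that something is new, unique, unknown or untested is made for them only; others in the source may bear on it.

Compound 1 `O=C1C=C(Nc2ccc(C(F)(F)F)cc2)C(=O)c2c1nc1n2[C@H]2OC[C@@H](O)[C@H]2OC1` gives 5500 nM in a functional assay on ECa-109 cells for inhibition, with ECa-109 cell line (Homo sapiens) as the target, read by sulforhodamine B assay; a lower number here means a stronger inhibitor, a higher number a weaker inhibitor.
Compound 2 `O=C1C=C(Nc2cccc(Cl)c2)C(=O)c2c1nc1n2[C@H]2OC[C@@H](O)[C@H]2OC1` gives 4690 nM.
Compound 3 `O=C1C=C(NC2CCCCC2)C(=O)c2c1nc1n2[C@H]2OC[C@@H](O)[C@H]2OC1` is reported only as a limit of the assay, > 16000 nM, and not as a number.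

Compound 3 therefore stands at the weak end of the three measured compounds, at the limit (the limit of > 16000 nM in this assay, at which 1 of the 3 values shown sits). It carries a cyclohexyl group on the amine nitrogen, where compound 1 and compound 2 carry aromatic rings. Both measured steps that exchange an aromatic ring for cyclohexyl raised the number: an at least 2.9-fold higher number from compound 1 to compound 3 (0.46 log units; beyond the scatter) and an at least 3.4-fold higher number from compound 2 to compound 3 (0.53 log units; beyond the scatter), each at least modest and beyond the scatter. The step between the two aromatic analogues, a 1.2-fold lower number from compound 1 to compound 2 (0.07 log units; within the scatter), lies within the scatter.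

Compound 4 `O=C1C=C(Nc2ccccc2F)C(=O)c2c1nc1n2[C@H]2OC[C@@H](O)[C@H]2OC1` is not yet measured in this assay. Its change from compound 3 is 2-fluorophenyl in place of cyclohexyl on an amine nitrogen. This reverses the direction of the two measured aryl-to-cyclohexyl steps, so a lower number, beyond the scatter, is expected for compound 4. Because compound 3 sits at the limit (the limit of > 16000 nM in this assay, at which 1 of the 3 values shown sits), the true size of the step can only be estimated as a minimum. Near the aromatic analogues, compound 4 is expected to land at 5000 nM, with a range from 2000 nM to 12000 nM. The estimated step of an at least 3.2-fold lower number from compound 3 to compound 4 (0.50 log units; beyond the scatter) thus mirrors what the two aryl-to-cyclohexyl steps showed.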

Compound 4, half-maximal inhibitory concentration: 2760 nM
Beside the measured number, compound 4's estimate is 1.8-fold (0.26 log units) above it, and the stated range covers the measured number.
By their numbers in this assay, from the lowest: compounds 4, 2 and 1 (each within the scatter of the next). At a limit, above all of these: compound 3.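

With 2-fluorophenyl on the amine nitrogen, the change from cyclohexyl gives an at least 5.7-fold lower number from compound 3 to compound 4 (0.76 log units; beyond the scatter), so a third aromatic ring now stands apart from cyclohexyl in this assay, and no compound shown goes against this. The new ring also widens the range of aromatic substituents without separating the compounds, since the change gives a 1.7-fold lower number from compound 2 to compound 4 (0.23 log units; within the scatter) and a 2.0-fold lower number from compound 1 to compound 4 (0.30 log units; within the scatter), which leaves 2-fluorophenyl, 3-chlorophenyl and 4-(trifluoromethyl)phenyl indistinguishable here. The step from cyclohexyl to 2-fluorophenyl is only a minimum because compound 3 is reported as a limit: the limit of > 16000 nM in this assay, at which 1 of the 4 values shown sits.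

The compounds shown leave open whether an unsubstituted phenyl ring would sit with the three aromatic compounds, and whether a benzyl group or a straight alkyl chain on the amine nitrogen would behave like the aromatic rings or like cyclohexyl. They also leave open whether a substituent of another kind on the aromatic ring, such as a carboxylic acid or a dimethylamino group, could move the number beyond the scatter.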